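Carbamoyl for isopropyl: an untested change on the shared core

The source may report more compounds than this note shows. Statements on the series, on what has been measured and on what is new or still open speak of the compounds shown alone.

Compound 1 `NCCCC[C@H](NC(=O)CN(c1nc(Cl)nc2[nH]cnc12)C1CC1)C(=O)OCc1ccccc1` gives 35.3% in a functional assay on the whole organism (Tail, strain ICR) with Mus musculus as the target, in the tail flick test, with a stated time of 90 min, at a dose of 25 umol/kg by the oral route; on this read-out higher numbers stand for a stronger effect at the one dose given and lower numbers for a weaker effect.
Compound 2 `CSCC[C@H](NC(=O)CN(c1nc(Cl)nc2[nH]cnc12)C1CC1)C(=O)OCc1ccccc1` gives 44.6% in this assay.
Compound 3 `CC(C)C[C@H](NC(=O)CN(c1nc(Cl)nc2[nH]cnc12)C1CC1)C(=O)OCc1ccccc1` gives 15.2% in this assay.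

Compound 3 stands lowest of the three in this assay; its nearest neighbour is compound 1, and compound 2 lies furthest from it, both gaps beyond the scatter. Compound 4 `NC(=O)C[C@H](NC(=O)CN(c1nc(Cl)nc2[nH]cnc12)C1CC1)C(=O)OCc1ccccc1` has not yet been measured in this assay. It differs from compound 3 in one place: carbamoyl in place of isopropyl on a saturated chain carbon, two bonds along the chain from an amide-type nitrogen and a carbonyl carbon.

Among the measured compounds shown here, two measured steps bear on this change, since both end at the isopropyl group that now leaves. The step of a number 20.1 percentage points lower from compound 1 to compound 3 (beyond the scatter) and the step of a number 29.4 percentage points lower from compound 2 to compound 3 (beyond the scatter) were both losses on arriving at isopropyl at the same position, whereas the step of a number 9.3 percentage points higher from compound 1 to compound 2 (within the scatter) between the two other groups stayed within the scatter. Nothing measured shows a carbamoyl at this position, so the size of its effect is open. On the pattern of the two steps toward compound 3, a return toward the range of compound 1 and compound 2 is expected when isopropyl is replaced, with the carbamoyl group of compound 4 counted as carrying one hydrogen-bond donor and one acceptor. Compound 4 is therefore expected to give 32% in this assay, within 12% to 55%, a step estimated as a number 16.8 percentage points higher from compound 3 to compound 4 (beyond the scatter).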

Compound 4, a percentage reported as activity, at one dose (the size of the read-out at that dose, not a potency): 32.3%
Estimate against measurement, compound 4: 0.3 percentage points below, within the range that was stated.
By their numbers in this assay, from the lowest: compound 3; then compounds 4, 1 and 2 (each within the scatter of the next, the first and the last beyond it).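

In this assay, among the compounds shown here, the earlier compounds compared isopropyl only with groups of other sizes, whereas carbamoyl carries the same count of heavy atoms as isopropyl, with 1 hydrogen-bond donor and 1 hydrogen-bond acceptor where isopropyl has none; the step is a number 17.1 percentage points higher from compound 3 to compound 4 (beyond the scatter), so a difference at this position appears even with the heavy-atom count unchanged. The position also now shows a finer separation among the three groups other than isopropyl: the step to carbamoyl from 3-aminopropyl is a number 3 percentage points lower from compound 1 to compound 4 (within the scatter), while the step from (methylsulfanyl)methyl is a number 12.3 percentage points lower from compound 2 to compound 4 (beyond the scatter). No measurement at hand gives a reason for these differences.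

Still open, going by these compounds, is how a carboxylic acid at this place, or a longer chain ending in carbamoyl, would compare with compound 4 and with compound 2. On these data alone, each figure is also the size of the effect at one dose and one time, so the order of these groups at other doses remains unknown.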